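A few compounds are considered here, and "the series" means these few. Any claim that something is new, unique, unknown or untested is made for them only; others in the source may bear on it.

Measured so far:
compound 1, `C=CC(=O)N1C(=O)CC(c2ccc(C(F)(F)F)cc2)Sc2ccccc21`: 38600 nM
compound 2, `C=CC(=O)N1C(=O)CC(c2ccc(OC)cc2)Sc2ccccc21`: 32900 nM
compound 3, `C=CC(=O)N1C(=O)CC(c2ccc(Cl)cc2)Sc2ccccc21`: 22600 nM

In a functional assay on NB-4 cells (Homo sapiens) for cytotoxicity, read by CCK-8 assay, with a stated time of 24 h (on this read-out lower numbers stand for stronger inhibition and higher numbers for weaker inhibition), compound 1 gives the highest of the three numbers; compound 2 is nearest, a 1.2-fold lower number from compound 1 to compound 2 (0.07 log units; within the scatter), and compound 3 furthest, a 1.7-fold lower number from compound 1 to compound 3 (0.23 log units; within the scatter), neither step passing the scatter. Compound 4, `C=CC(=O)N1C(=O)CC(c2ccc(C(=O)OC)cc2)Sc2ccccc21`, is not yet measured. It differs from compound 1 in one place: methoxycarbonyl in place of trifluoromethyl on an aromatic carbon. Among the compounds with values here, the steps that bear on this change are the two other swaps on the same aromatic carbon, a 1.2-fold lower number from compound 1 to compound 2 (0.07 log units; within the scatter) and a 1.7-fold lower number from compound 1 to compound 3 (0.23 log units; within the scatter), both within scatter, as is a 1.5-fold lower number from compound 2 to compound 3 (0.16 log units; within the scatter). Exchanging the group on that carbon has so far left this assay essentially unmoved, so no step beyond the scatter is expected in either direction. Compound 4 is estimated at 30000 nM, range 14000 nM to 65000 nM. That estimate means an expected step of a 1.3-fold lower number from compound 1 to compound 4 (0.11 log units; within the scatter).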

Compound 4, half-maximal inhibitory concentration: 24400 nM
For compound 4 the middle estimate is 1.2-fold (0.09 log units) above the measured one; the measured number falls inside the stated range.
By their numbers in this assay, from the lowest: compounds 3, 4, 2 and 1 (each within the scatter of the next).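

Methoxycarbonyl brings hydrogen-bond acceptors and a double bond outside aromatic rings in place of trifluoromethyl, yet in this assay the steps of a 1.6-fold lower number from compound 1 to compound 4 (0.20 log units; within the scatter) and a 1.1-fold higher number from compound 3 to compound 4 (0.03 log units; within the scatter) and a 1.3-fold lower number from compound 2 to compound 4 (0.13 log units; within the scatter) all stay within the scatter. This position on the aromatic carbon thus tolerates a carbonyl-bearing group without a readable shift, and compounds 1 to 4 cannot be ordered by this substituent. No measurement shown bears on the reason for this. As far as these compounds go, whether an amine or a carboxylic acid on this carbon would produce a step beyond the scatter remains open. So does the effect of any change elsewhere on the shared core.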